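Urea series: cytotoxicity on Raji cells, methoxy for chloro

A few compounds are considered here, and "the series" means these few. Any claim that something is new, unique, unknown or untested is made for them only; others in the source may bear on it.

Measured compounds:
compound 1 `COc1cccc(NC(=O)Nc2cc(C)nc3ccccc23)c1`, > 25000 nM
compound 2 `Cc1cc(NC(=O)Nc2ccc(Cl)cc2)c2ccccc2n1`, > 25000 nM
compound 3 `Cc1cc(NC(=O)Nc2cccc(Cl)c2)c2ccccc2n1`, 18000 nM

All three share one core and differ only in the phenyl ring on the urea nitrogen. In an ADME assay on Raji cells (Homo sapiens) for cytotoxicity, with a stated time of 72 h (a lower number here means that less compound is needed, a higher number that more compound is needed for the effect), compound 3 gives 18000 nM. In this assay compound 2 gives > 25000 nM, which is a limit of the assay and not a number. Compound 1 likewise gives > 25000 nM in this assay, again a limit. Two of the three values therefore sit at the same limit (the limit of > 25000 nM in this assay, at which 2 of the 3 values shown sit).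

Compound 2 and compound 3 differ in how the same atoms are joined: 4-chlorophenyl in place of 3-chlorophenyl on an amide-type nitrogen. The measured step is an at least 1.3-fold lower number from compound 2 to compound 3 (0.14 log units; that floor lies within the scatter). From compound 3 to compound 1 the change is methoxy in place of chloro on an aromatic carbon, and the step is an at least 1.3-fold higher number from compound 3 to compound 1 (0.14 log units; that floor lies within the scatter).

Compound 4 `COc1ccc(NC(=O)Nc2cc(C)nc3ccccc23)cc1` is not yet measured. It arises from compound 2 by methoxy in place of chloro on an aromatic carbon. This is the same kind of change as from compound 3 to compound 1, but the place differs: in compound 1 the methoxy is meta to a large group, in compound 4 it is para to a large group.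

For compound 4 the expected step is a step that the limit leaves unreadable from compound 2 to compound 4, resting on the step of an at least 1.3-fold higher number from compound 3 to compound 1 (0.14 log units; that floor lies within the scatter) and on compound 2 already sitting at the limit (the limit of > 25000 nM in this assay, at which 2 of the 3 values shown sit). Compound 4 is thus estimated at 40000 nM, most likely reported only as a limit, with a range from 18000 nM to 120000 nM.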

Compound 4, half-maximal effective concentration: > 25000 nM
Compound 4: a limit, no number; the forecaster's own chance of this, stated with the estimate: 85%; the middle value does not contradict the limit.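

Compound 2 and compound 4 both stand at a limit of the assay and not at a number, so no step between them can be read in this assay: the limit of > 25000 nM in this assay, at which 3 of the 4 values shown sit.

The compounds shown leave open whether methoxy in place of chloro, para to a large group, changes the number at all, and how far compound 2 and compound 4 lie beyond that limit.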